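The compounds below may be only part of what the source reports. "The series", "measured", "known", "first", "only" and "open" are said of these compounds alone.

Compound 2 `O=C(NC[C@@H]1CCCC[C@H]1O)NC1CCN(Cc2ccn(-c3ccc(C(F)(F)F)cc3)c2)CC1` sits at the stronger end of the two results available in an assay on HEK293 cells for displacement of a labelled ligand from melanin-concentrating hormone receptor 1 (Homo sapiens) (a higher number here means a weaker inhibitor, a lower number a stronger inhibitor), where compound 2 gives 46 nM. Among the compounds with values here, the only comparison is with compound 1 `O=C(NC1CCN(Cc2ccn(-c3ccc(C(F)(F)F)cc3)c2)CC1)NS(=O)(=O)c1ccc(F)cc1`, which in this assay gives 617 nM; the move a 13-fold lower number from compound 1 to compound 2 (1.13 log units; beyond the scatter) is the single step on record that bears on the nitrogen in question.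

Compound 3 `O=C(O)CC(NC(=O)NC1CCN(Cc2ccn(-c3ccc(C(F)(F)F)cc3)c2)CC1)c1ccccc1` alters compound 2 at that same place: 2-carboxy-1-phenylethyl in place of (2-hydroxycyclohexyl)methyl on an amide-type nitrogen. The change cut one bond further out reads ((2-hydroxycyclohexyl)methyl)amino to (2-carboxy-1-phenylethyl)amino. Within the data shown here, no measured pair contains the entering group, so the expectation leans on the one step that does touch this nitrogen, where replacing an aryl-bearing group by the (2-hydroxycyclohexyl)methyl group gave the large gain from compound 1 to compound 2. Compound 3 takes that group away again and brings in a group carrying an aromatic ring, so a step back toward weaker binding, yet short of the full distance, is expected in this assay, namely a 6.5-fold higher number from compound 2 to compound 3 (0.81 log units; beyond the scatter). For compound 3 the estimate in this assay is therefore 300 nM, with a likely range from 80 nM to 1200 nM.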

Compound 3, half-maximal inhibitory concentration: 412 nM
The estimate for compound 3 lay 1.4-fold (0.14 log units) below the measured number, and the stated range covers the measured number.
By their numbers in this assay, from the lowest: compound 2; then compounds 3 and 1 (each within the scatter of the next).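

Removing the (4-fluorophenyl)sulfonyl group does not by itself secure the low number of compound 2 in this assay: 2-carboxy-1-phenylethyl on the same amide-type nitrogen gives up much of that gain (a 9.0-fold higher number from compound 2 to compound 3 (0.95 log units; beyond the scatter)). The other comparison at this nitrogen (a 1.5-fold lower number from compound 1 to compound 3 (0.18 log units; within the scatter)) lies within the scatter, so compound 1 and compound 3 cannot be told apart, even though the groups they carry there differ. Of the three groups compared at this place, only (2-hydroxycyclohexyl)methyl stands apart in this assay, and no measurement offered here explains why.

The compounds shown do not separate the contribution of the hydroxyl from that of the carbon ring in (2-hydroxycyclohexyl)methyl, a question that a plain cyclohexylmethyl group would address. Nor do they show whether the carboxylic acid or the phenyl ring of 2-carboxy-1-phenylethyl goes with the higher number, which a methyl ester, a primary amide or a 2-carboxyethyl chain at the same nitrogen would begin to separate.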